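The source may hold more compounds than are shown below. What is called first, only, known or untested is meant among the compounds shown, and "the series" means these compounds.

Measured compounds in a functional assay on the whole organism (strain albino) for inhibition, with Rattus norvegicus as the target, read by paw edema, in the formalin test, with a stated time of 1 h, at a dose of 10 mg/kg by the oral route; a higher number here means more inhibition at the dose given (going by the name of the read-out), a lower number less inhibition:
compound 1 `Cc1c(C(N)=O)sc2nc(NN)n(Cc3ccccc3)c(=O)c12` gives 43%
compound 2 `Cc1c(C(N)=O)sc2nc(N/N=C/c3ccc(Br)cc3)n(Cc3ccccc3)c(=O)c12` gives 34%
compound 3 `Cc1c(C(N)=O)sc2nc(-n3nc(-c4ccc(Cl)cc4)cc3N)n(Cc3ccccc3)c(=O)c12` gives 30%

Compound 2 sits among these three numbers with no gap beyond the usual scatter: the step of a number 9 percentage points lower from compound 1 to compound 2 (within the scatter) is within the scatter, and its distance to compound 3 is also within it. Compound 4 `Cc1cc(C)n(-c2nc3sc(C(N)=O)c(C)c3c(=O)n2Cc2ccccc2)n1` differs from compound 2 by a group of 7 heavy atoms (5 carbon, 2 nitrogen; one five-membered aromatic ring with 2 hetero atoms) in place of a group of 10 heavy atoms (7 carbon, 2 nitrogen, 1 bromine; one six-membered aromatic ring of carbon only), on an aromatic carbon. Going by the values given here, the only measured step, from compound 1 to compound 2, concerns a different attachment point and was within the scatter; no measured pair exchanges a six-membered carbon ring for a 3,5-dimethyl-1H-pyrazol-1-yl group. Compound 3, which also carries a five-membered ring on the core carbon, gives a number close to compound 2. Compound 4 is therefore expected near compound 2, with the step of a number 2 percentage points lower from compound 2 to compound 4 (within the scatter) estimated as within the scatter. The estimate for compound 4 is 32%, with a range from 18% to 46%.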

Compound 4, a percentage reported as inhibition, in the whole organism at one dose (the size of the read-out at that dose, not a potency): 32%
Compound 4: the middle estimate sits on the measured number at the digits printed, within the range that was stated.
By their numbers in this assay, from the lowest: compounds 3, 4, 2 and 1 (each within the scatter of the next, the first and the last beyond it).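

In this assay, the position between two ring nitrogen atoms accepts 3,5-dimethyl-1H-pyrazol-1-yl in place of the larger group with the six-membered carbon ring and bromine, with a number 2 percentage points lower from compound 2 to compound 4 (within the scatter). Replacing aminoamino with the same pyrazole gives a number 11 percentage points lower from compound 1 to compound 4 (beyond the scatter), a modest step, but one that passes beyond the scatter. No measurement here bears on the reason for either result.

From the compounds shown here alone, whether a morpholine ring or a pyrazole without methyl groups at this position would fall nearer compound 1 or compound 4 remains open.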